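The source may hold more compounds than are shown below. What is called first, only, known or untested is meant among the compounds shown, and "the series" means these compounds.

In a toxicity assay on THP-1 cells (Homo sapiens) for inhibition (on this read-out lower numbers stand for higher toxicity in this test and higher numbers for lower toxicity in this test), three amides on a shared core have been read so far. Compound 1 (`COc1ccc(-c2cnc(NC(=O)CCc3ccccc3)n2C)cc1`) gives > 100000 nM as a limit of the assay, not a number. Compound 2 (`COc1ccc(-c2cnc(NC(=O)c3ccco3)n2C)cc1`) gives > 100000 nM, again a limit. Compound 3 (`COc1ccc(-c2cnc(NC(=O)c3ccc(C#N)cc3)n2C)cc1`) gives > 100000 nM, also a limit. It therefore stands with the others at the limit of > 100000 nM in this assay, at which 3 of the 3 values shown sit.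

The next step leads to compound 4 (`COc1ccc(-c2cnc(NC(=O)c3ccccn3)n2C)cc1`), with pyridin-2-yl in place of 4-cyanophenyl on a carbonyl carbon. Three measured steps changed the group at this same place: a step that the two limits leave unreadable from compound 1 to compound 2, a step that the two limits leave unreadable from compound 1 to compound 3 and a step that the two limits leave unreadable from compound 2 to compound 3. The size of each is unreadable, and none of the three compounds gave a number in this assay. No change beyond the scatter is therefore expected, and any real shift could not be read if compound 4 also meets the limit. The expected step is a number no higher from compound 3 to compound 4 (the limit leaves the size open). The estimate for compound 4 is 100000 nM, with an expected range from 50000 nM to 200000 nM.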

Compound 4, half-maximal cytotoxic concentration: > 100000 nM
Compound 4: only a limit was reported (the forecaster's own chance of this, stated with the estimate: 90%); the middle value sits exactly at the limit.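

In this assay, for the compounds shown here, compound 4 gives > 100000 nM as a limit of the assay and not a number, so no step from compound 1, compound 2 or compound 3 to compound 4 can be read. The compounds shown leave open whether changing the group on the carbonyl carbon shifts this read-out at all.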